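The compounds below may be only part of what the source reports. "The series", "measured", "known", "first", "only" and "open" are said of these compounds alone.

Compound 1, `OC(CCn1nc2c(Br)c(Br)c(Br)c(Br)c2n1)c1ccc(F)cc1`, is the weakest of the three compounds measured in a functional assay on CCRF-CEM cells (Homo sapiens) for antiproliferative activity, read by MTT assay, with a stated time of 48 h, tested at 25 uM (a lower number here means a stronger effect, a higher number a weaker effect of the compound at the concentration tested), where compound 1 gives 88%. Its nearest neighbour is compound 3, `C[C@@H](O)CCn1nc2c(Br)c(Br)c(Br)c(Br)c2n1`, which gives 71%, and the furthest is compound 2, `COc1cccc(C(O)CCn2nc3c(Br)c(Br)c(Br)c(Br)c3n2)c1`, which gives 50%.

Compound 4, `CC(O)CCn1nc2c(Br)c(Br)c(Br)c(Br)c2n1`, differs from compound 1 in one place: methyl in place of 4-fluorophenyl on a saturated chain carbon bound to an oxygen on a saturated carbon and a saturated chain carbon. For the measured compounds named here, one measured step touches the same place. Exchanging the 4-fluorophenyl of compound 1 for another group gave a number 38 percentage points lower from compound 1 to compound 2 (beyond the scatter), a clear strengthening of the effect. Compound 3 also carries a methyl at this place, so its value bears on compound 4 as well.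

Because compound 3 already shows 71% with a methyl at this place, and because removing the 4-fluorophenyl gave a number 38 percentage points lower from compound 1 to compound 2 (beyond the scatter), the step from compound 1 to compound 4 is expected to lower the number, as a number 17 percentage points lower from compound 1 to compound 4 (beyond the scatter). For compound 4 the estimated value in this assay is 71%, expected to lie between 58% and 84%.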

Compound 4, a percentage reported as activity, at one concentration (the size of the read-out at that concentration, not a potency): 86%
Estimate against measurement, compound 4: 15 percentage points below; the measured number lies above the stated range.
By their numbers in this assay, from the lowest: compound 2; then compound 3; then compounds 4 and 1 (each within the scatter of the next).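

In this assay, methyl in place of 4-fluorophenyl gives a number 2 percentage points lower from compound 1 to compound 4 (within the scatter), while compound 2 stands apart from the methyl compound, with a number 36 percentage points higher from compound 2 to compound 4 (beyond the scatter). An aromatic ring at this place is therefore not enough for a stronger effect, since only the 3-methoxyphenyl of compound 2 goes with one, and the 4-fluorophenyl of compound 1 does not. The atoms and bonds do not account for a number 15 percentage points higher from compound 3 to compound 4 (beyond the scatter), and the only difference printed for this pair is one of drawn configuration: the fact that one of compounds 3 and 4 is drawn with a defined configuration and the other without, at the place where they differ

From the compounds shown here alone, what remains open is what compound 4 contains as a sample and how the opposite configuration to compound 3 would read. Also open, going by these compounds, is whether the methoxy group itself matters, which a plain phenyl or a 4-methoxyphenyl at this place would help to separate.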